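A few compounds are considered here, and "the series" means these few. Any claim that something is new, unique, unknown or untested is made for them only; others in the source may bear on it.

Measured compounds:
- compound 1 `CC[C@H](C)[C@H](N)CN(C(=O)[C@@H]1C[C@H]1c1cccc(Cl)c1)c1ccc(-c2ccccc2)cc1` gives 2200 nM in a functional assay for agonist activity at G protein-coupled receptor 88 (Homo sapiens), read by HTRF and cAMP accumulation; a lower number here means that less compound is needed, a higher number that more compound is needed for the effect.
- compound 2 `CC[C@H](C)[C@H](N)CN(C(=O)[C@@H]1C[C@H]1c1ccc(C#N)cc1)c1ccc(-c2ccccc2)cc1` gives > 25000 nM in this assay.

Compound 2 stands only at a limit of this assay, not at a number: it sits at the limit of > 25000 nM in this assay, at which 1 of the 2 values shown sits. The gap to compound 1 is therefore known only as an at least 11-fold higher number from compound 1 to compound 2 (1.05 log units; beyond the scatter), a large step beyond the scatter, for the exchange of 3-chlorophenyl against 4-cyanophenyl on the saturated ring carbon.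

Compound 3 `CC[C@H](C)[C@H](N)CN(C(=O)[C@@H]1C[C@H]1c1ccc(F)c(F)c1)c1ccc(-c2ccccc2)cc1` is not yet measured. It differs from compound 2 by 3,4-difluorophenyl in place of 4-cyanophenyl on a saturated ring carbon, so the nitrile-bearing ring leaves and a difluorinated phenyl enters. Going by the values given here, the only measured step that bears on this change is the one between compound 1 and compound 2, where a halogen-bearing phenyl at this position gave a number and the 4-cyanophenyl gave only the limit. Compound 3 returns halogen to the phenyl, and a drop in this assay from the limit of compound 2 is therefore expected, of the size of an at least 7.1-fold lower number from compound 2 to compound 3 (0.85 log units; beyond the scatter), back toward the region of compound 1, though how far it reaches is uncertain. Compound 3 is estimated at 3500 nM, within a range of 800 nM to 20000 nM.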

Compound 3, half-maximal effective concentration: 720 nM
Compound 3: the middle estimate sits 4.9-fold (0.69 log units) above what was measured, outside the stated range (below it).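

In this assay, the aryl group on the saturated ring carbon of the three-membered ring does more than separate a measurable compound from an inactive-looking one, since two halogen-bearing phenyl groups also differ from each other: a 3.1-fold lower number from compound 1 to compound 3 (0.49 log units; beyond the scatter), a modest step in favour of 3,4-difluorophenyl over 3-chlorophenyl. The exchange of 4-cyanophenyl for 3,4-difluorophenyl is much larger, an at least 34-fold lower number from compound 2 to compound 3 (1.54 log units; beyond the scatter), which makes this place in the core of compound 1 sensitive to the aryl group in both the large and the modest range. Compound 2 stands at a limit and not at a number, so the size of that large step is a bound only: the limit of > 25000 nM in this assay, at which 1 of the 3 values shown sits.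

The two halogen-bearing compounds differ in both the halogen and its ring location, so compound 1 and compound 3 do not show whether fluorine, the second halogen or the substitution pattern accounts for their gap; 3-fluorophenyl, 4-fluorophenyl and 3,4-dichlorophenyl would separate these. Likewise, 3-cyanophenyl would show whether the nitrile itself or its location on the ring goes with the limit seen for compound 2.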